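Changing the Halogenated Phenyl Ether on a Shared Core

The source may hold more compounds than are shown below. What is called first, only, known or untested is meant among the compounds shown, and "the series" means these compounds.

Two measured compounds share one core and differ only in the phenyl group joined to it through an oxygen on an aromatic ring. Compound 1 `Cc1nn(C)c(Oc2ccc(F)cc2F)c1/C=N\CCCCCCOc1cc2oc(=O)cc(C)c2cc1Cl` carries 2,4-difluorophenyl there. In a functional assay on SMMC-7721 cells (Homo sapiens) for antiproliferative activity, read by MTT assay, with a stated time of 72 h (a lower number here means a stronger inhibitor, a higher number a weaker inhibitor), compound 1 gives only a limit, > 25000 nM (the limit of > 25000 nM in this assay, at which 1 of the 2 values shown sits). Among the compounds with values here, compound 2 `Cc1nn(C)c(Oc2ccc(Cl)cc2)c1/C=N\CCCCCCOc1cc2oc(=O)cc(C)c2cc1Cl` carries 4-chlorophenyl instead, and in this assay compound 2 gives 2080 nM, the only full number so far. The step of an at least 12-fold lower number from compound 1 to compound 2 (1.07 log units; beyond the scatter) shows that this phenyl group alone can move the read-out a long way.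

Compound 3 `Cc1nn(C)c(Oc2ccccc2Br)c1/C=N\CCCCCCOc1cc2oc(=O)cc(C)c2cc1Cl` is not yet measured; it differs from compound 2 by 2-bromophenyl in place of 4-chlorophenyl on an oxygen on an aromatic ring. Within the data shown here, the single measured step, an at least 12-fold lower number from compound 1 to compound 2 (1.07 log units; beyond the scatter), bears on this change only loosely: it shows a large effect of the phenyl group, but with another pattern of halogens, so the direction for compound 3 is open. Compound 3 is therefore expected near 5000 nM, within 1200 nM to 25000 nM. That estimate means an expected step of a 2.4-fold higher number from compound 2 to compound 3 (0.38 log units; beyond the scatter).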

Compound 3, half-maximal inhibitory concentration: 19700 nM
Compound 3: the middle estimate sits 3.9-fold (0.60 log units) below what was measured, and the stated range covers the measured number.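

In this assay, the step of a 9.5-fold higher number from compound 2 to compound 3 (0.98 log units; beyond the scatter) shows that carrying a single halogen on the phenyl group is not enough to keep the reading of compound 2, since 2-bromophenyl also carries just one. The step of an at least 1.2-fold lower number from compound 1 to compound 3 (0.10 log units; that floor lies within the scatter) has a floor that lies within the scatter, so 2-bromophenyl and 2,4-difluorophenyl cannot be put in order here. Compound 1 gives only a limit, and that comparison stays unresolved for this reason: the limit of > 25000 nM in this assay, at which 1 of the 3 values shown sits.

Going from compound 2 to compound 3 changes the halogen and its place on the ring together, so these compounds cannot show which of the two drives the step. From the compounds shown here alone, a 4-bromophenyl or 2-chlorophenyl group would separate the two, while plain phenyl and 4-methoxyphenyl remain open cases.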